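This account rests on a few compounds, and the source may have more. Where it says the series, first, only, none or still open, it means among the compounds named here.

- compound 1 `COc1ccc(C(=O)Nc2ccc3c(c2)/C(=C/Nc2cccc(N4CCN(C)CC4)c2)C(=O)N3)cc1`: 1870 nM
- compound 2 `CN1CCN(c2cccc(N/C=C3\C(=O)Nc4ccc(NC(=O)c5c(F)cccc5F)cc43)c2)CC1`: 1630 nM

In a functional assay on NCI-H1650 cells (Homo sapiens) for inhibition, read by sulforhodamine B assay, with a stated time of 3 days (on this read-out lower numbers stand for stronger inhibition and higher numbers for weaker inhibition), compound 2 gives 1630 nM, level with compound 1 within the scatter. Compound 3 `CN1CCN(c2cccc(N/C=C3\C(=O)Nc4ccc(NC(=O)c5c(Cl)cccc5Cl)cc43)c2)CC1` differs from compound 2 by 2,6-dichlorophenyl in place of 2,6-difluorophenyl on a carbonyl carbon. For the measured compounds named here, only one measured step changed the group at this place, a 1.1-fold lower number from compound 1 to compound 2 (0.06 log units; within the scatter), and it stayed small. On that single step, the expected change is none beyond the scatter, an estimated 1.0-fold lower number from compound 2 to compound 3 (0.01 log units; within the scatter). Compound 3 is therefore expected at about 1600 nM, within an estimated range of 700 nM to 3600 nM.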

Compound 3, half-maximal inhibitory concentration: 2170 nM
For compound 3 the middle estimate is 1.4-fold (0.13 log units) below the measured one; low and high end bracket the measured number.
By their numbers in this assay, from the lowest: compounds 2, 1 and 3 (each within the scatter of the next).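

In this assay, exchanging the two fluorines for two chlorines leaves the number within the scatter (a 1.3-fold higher number from compound 2 to compound 3 (0.12 log units; within the scatter)), and the exchange from 4-methoxyphenyl does the same (a 1.2-fold higher number from compound 1 to compound 3 (0.06 log units; within the scatter)). For the compounds shown here, the single earlier step compared only two groups on this carbonyl carbon; now 2,6-difluorophenyl, 2,6-dichlorophenyl and 4-methoxyphenyl all read alike. Nothing available accounts for this sameness. Still open, on these data alone, is whether a group of another kind on this carbonyl carbon, such as a plain alkyl chain or a phenyl carrying a carboxylic acid, would move the number beyond the scatter.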